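The source may report more compounds than this note shows. Statements on the series, on what has been measured and on what is new or still open speak of the compounds shown alone.

Values measured in an in vitro ADME assay on the whole organism (small intestine) for pharmacokinetics, with Rattus norvegicus as the target; a higher number here means that the compound lasts longer, a lower number that the compound disappears faster:

- Compound 1 `CCOC(=O)CN(C(=O)/C(C)=C/c1ccc(C(=O)Oc2ccc(C(=N)N)cc2)cc1)C1CCCC1`: > 1 h (a limit of the assay, not a number)
- Compound 2 `CCOC(=O)CN(Cc1ccccc1)C(=O)/C(C)=C/c1ccc(C(=O)Oc2ccc(C(=N)N)cc2)cc1`: 0.733 h
- Compound 3 `C/C(=C\c1ccc(C(=O)Oc2ccc(C(=N)N)cc2)cc1)C(=O)N(CC(=O)O)C1CCCC1`: 0.7 h

Compound 3 gives 0.7 h, and compound 2 gives 0.733 h. These two values lie within the scatter of each other. Compound 1 has a limit as its only result, > 1 h, so compound 3 cannot be placed exactly against it.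

The next compound is compound 4 `C=CCN(CCC(=O)OCC)C(=O)/C(C)=C/c1ccc(C(=O)Oc2ccc(C(=N)N)cc2)cc1`, and the change is allyl(2-(ethoxycarbonyl)ethyl)amino in place of (carboxymethyl)(cyclopentyl)amino on a carbonyl carbon. Going by the values given here, two measured steps bear on this change. One is an at least 1.4-fold lower number from compound 1 to compound 3 (0.15 log units; that floor lies within the scatter), which puts hydrogen in place of ethyl on an oxygen. Compound 4 carries ethoxycarbonyl again, so this step applies in reverse. The other is an at least 1.3-fold lower number from compound 1 to compound 2 (0.13 log units; that floor lies within the scatter), which replaces cyclopentyl with benzyl. Both are floors that lie within the scatter, so neither shows a change beyond it. Among the compounds with values here, no measured compound carries allyl or the 2-(ethoxycarbonyl)ethyl chain, so this part of the change is untested.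

Any shift in this assay is expected to be small and, if it shows at all, upward. The expected size is a 1.3-fold higher number from compound 3 to compound 4 (0.11 log units; within the scatter), which does not go beyond the scatter. For compound 4 the estimated half-life is 0.9 h, with an expected range of 0.45 h to 1.8 h.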

Compound 4, half-life: 1 h
Beside the measured number, compound 4's estimate is 1.1-fold (0.05 log units) below it; low and high end bracket the measured number.
By their numbers in this assay, from the lowest: compounds 3, 2 and 4 (each within the scatter of the next).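

In this assay, exchanging the entire group on the carbonyl carbon gives a 1.4-fold higher number from compound 3 to compound 4 (0.15 log units; within the scatter). Going by these compounds alone, this is the first measured case of an open-chain group at this place: allyl(2-(ethoxycarbonyl)ethyl)amino has no ring and an ester rather than the free acid of compound 3, yet compound 4 stays within the scatter of compound 3. Compound 1 has only a limit as its result, so compound 4 cannot be placed exactly against it, and that limit is recorded here: the limit of > 1 h in this assay, at which 1 of the 4 values shown sits.

The step also changes the ring, the chain and the ester together, so the compounds shown leave open how much each of these parts contributes, a question that compounds changing only one of them, such as cyclopentyl kept with the 2-(ethoxycarbonyl)ethyl chain, could settle. Going by these compounds, it also remains open how this place would respond to a group of another kind, such as a chain ending in an amine, or to a longer chain than those seen here.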